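This account rests on a few compounds, and the source may have more. Where it says the series, first, only, none or still open, it means among the compounds named here.

Three compounds carry numbers in a functional assay on KB3 cells (Homo sapiens) for antiproliferative activity, read by MTT assay, with a stated time of 96 h; a higher number here means a weaker inhibitor, a lower number a stronger inhibitor. Compound 1 `C=C(C)[C@H]1CC=C(C)C2=CO[C@@H](c3ccco3)[C@@H]21` gives 2000 nM. Compound 2 `C=C(C)[C@H]1CC(=O)C(C)=C2[C@@H](C(=O)OCC)O[C@@H](c3cccc(Br)c3)[C@@H]21` gives 30000 nM. Compound 3 `C=C(C)[C@H]1CC(=O)C(C)=C2[C@@H](C(=O)OCC)O[C@@H](c3cccc(Cl)c3Cl)[C@@H]21` gives 5000 nM, the second highest of the three numbers, with compound 1 standing nearer to it and compound 2 further away. Going by the values given here, the only step between measured compounds that differ in one place runs a 6.0-fold lower number from compound 2 to compound 3 (0.78 log units; beyond the scatter), a modest change that lies beyond the scatter. Compound 4 `C=C(C)[C@H]1CC(=O)C(C)=C2[C@@H](C(=O)OCC)O[C@@H](c3ccccc3Br)[C@@H]21` differs from compound 3 by 2-bromophenyl in place of 2,3-dichlorophenyl on a saturated ring carbon. The step from compound 2 to compound 3 bears on this change: there a 3-bromophenyl group gave way to the 2,3-dichlorophenyl group and the number fell. Compound 4 again carries a single bromine on the ring, now as 2-bromophenyl, a group not found among the measured compounds. Compound 4 is therefore expected to show a modest rise in this assay, the expected step being a 2.4-fold higher number from compound 3 to compound 4 (0.38 log units; beyond the scatter). The estimate for compound 4 is 12000 nM, with a range from 4000 nM to 40000 nM.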

Compound 4, half-maximal inhibitory concentration: 70000 nM
The estimate for compound 4 lay 5.8-fold (0.77 log units) below the measured number; the whole stated range lies below it.
By their numbers in this assay, from the lowest: compound 1; then compound 3; then compound 2; then compound 4.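

Going by these compounds alone, on the saturated ring carbon next to the ring oxygen, the change from 2,3-dichlorophenyl to 2-bromophenyl in this assay gives a 14-fold higher number from compound 3 to compound 4 (1.15 log units; beyond the scatter), a larger step than any seen among the earlier compounds. The place of the single bromine on the phenyl ring also counts, as moving from 3-bromophenyl to 2-bromophenyl gives a 2.3-fold higher number from compound 2 to compound 4 (0.37 log units; beyond the scatter), and both bromophenyl compounds stand at higher numbers than the 2,3-dichlorophenyl compound, compound 3. Nothing available accounts for these differences.

The compounds shown leave open whether the gain belongs to the two chlorines or to their pattern on the ring, which 2-chlorophenyl, 3-chlorophenyl or 2,3-dibromophenyl groups could separate. They also leave open how a phenyl ring carrying an amine or a methoxy group would fare at this position.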